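A few compounds are considered here, and "the series" means these few. Any claim that something is new, unique, unknown or untested is made for them only; others in the source may bear on it.

Working notes on the anilino-nitrile series.

Two compounds carry numbers in a functional assay on MGC-803 cells (Homo sapiens) for inhibition, read by MTT assay, with a stated time of 72 h (a lower number here means a stronger inhibitor, a higher number a weaker inhibitor), so far. Compound 1 `C#CCSc1nc(Nc2ccccc2Cl)c(C#N)c(-c2ccccc2)n1` gives 52800 nM in this assay. Compound 2 `N#Cc1c(Nc2cccc(C(F)(F)F)c2)nc(SCc2cn(Cc3ccccc3Cl)nn2)nc1-c1ccccc1` gives 22800 nM in this assay, the lower of the two values; compound 1 sits at a number beyond the scatter above it. The two structures differ in more than one place, so their gap cannot be pinned on a single change.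

Compound 3 `N#Cc1c(Nc2ccc(Cl)cc2)nc(SCc2cn(Cc3ccccc3Cl)nn2)nc1-c1ccccc1` is the next one to be run. It departs from compound 2 in one place: 4-chlorophenyl in place of 3-(trifluoromethyl)phenyl on a nitrogen on an aromatic ring. Among the measured compounds shown here, no measured pair in this set isolates that exchange, so there is no step to lean on. The expectation is a step from compound 2 of a 1.1-fold higher number from compound 2 to compound 3 (0.04 log units; within the scatter), that is, nothing clearly beyond the scatter in either direction. Compound 3 is estimated at 25000 nM in this assay, with a range of 8000 nM to 75000 nM.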

Compound 3, half-maximal inhibitory concentration: 5850 nM
Compound 3: middle estimate off by 4.3-fold (0.63 log units), on the high side, outside the stated range (below it).
By their numbers in this assay, from the lowest: compound 3; then compound 2; then compound 1.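

In this assay, the group on the nitrogen on an aromatic ring proves to be a position that moves the number: 4-chlorophenyl in place of 3-(trifluoromethyl)phenyl gives a 3.9-fold lower number from compound 2 to compound 3 (0.59 log units; beyond the scatter) while the rest of the structure stays fixed. Among the compounds shown here, this is the first single-place step, and it places compound 3 lowest of the three compounds; compound 1 differs from the other two in more than one place and does not bear on this exchange. Nothing available accounts for the size or direction of this step, so it stands as an observation only.

This single exchange cannot separate the loss of trifluoromethyl, the arrival of chlorine and the changed place on the ring from one another. On these data alone, how a methoxy group or an amine on that ring would read also remains open.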